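This account rests on a few compounds, and the source may have more. Where it says the series, first, only, none or still open, it means among the compounds named here.

Compound 1 `O=C(Nc1cccc([N+](=O)[O-])c1)N[C@H]1CC[C@H](Oc2ccc(F)cc2)CC1` gives in a functional assay on CRL2813 cells (Homo sapiens) for cytotoxicity, read by sulforhodamine B assay, with a stated time of 5 days (a lower number here means a stronger inhibitor, a higher number a weaker inhibitor), 6700 nM. Compound 2 `O=C(Nc1ccccc1I)N[C@H]1CC[C@H](Oc2ccc(F)cc2)CC1` reaches only the limit of this assay, > 20000 nM. Compound 3 `O=C(Nc1ccccc1OC(F)(F)F)N[C@H]1CC[C@H](Oc2ccc(F)cc2)CC1` likewise sits at the limit, > 20000 nM.

Compound 2 thus stands at the limit of > 20000 nM in this assay, at which 2 of the 3 values shown sit, with no number of its own. The change to compound 4 `CSc1ccc(NC(=O)N[C@H]2CC[C@H](Oc3ccc(F)cc3)CC2)cc1` is 4-(methylsulfanyl)phenyl in place of 2-iodophenyl on an amide-type nitrogen. Going by the values given here, the one step that speaks to swapping the aryl group on that nitrogen is an at least 2.9-fold higher number from compound 1 to compound 2 (0.47 log units; beyond the scatter), while a step that the two limits leave unreadable from compound 2 to compound 3 gives nothing usable. With compound 2 known only as a limit, the estimated step of an at least 1.6-fold lower number from compound 2 to compound 4 (0.22 log units; that floor lies within the scatter) is an expectation whose direction cannot be read from the measurements, and only the value of compound 1 anchors it. Compound 4 is therefore estimated at 12000 nM, within 3000 nM to 40000 nM.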

Compound 4, half-maximal inhibitory concentration: > 20000 nM
Compound 4 was reported as a limit; the forecaster's own chance of this, stated with the estimate: 45%; at least 1.6-fold (0.22 log units) between middle value and limit.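

In this assay compound 4 is reported only as a limit, which adds a third aryl group to those at that limit: the limit of > 20000 nM in this assay, at which 3 of the 4 values shown sit. Putting 4-(methylsulfanyl)phenyl in place of 3-nitrophenyl on the amide-type nitrogen gives an at least 2.9-fold higher number from compound 1 to compound 4 (0.47 log units; beyond the scatter), so a second swap away from 3-nitrophenyl now ends at the limit. The steps between limits cannot be read, so 4-(methylsulfanyl)phenyl and 2-iodophenyl cannot be ordered.

As far as these compounds go, it remains open how far these compounds lie past the limit. From the compounds shown here alone, it is also open whether an amine or a carboxylic acid on that aryl ring would give a measurable value.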